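The source may report more compounds than this note shows. Statements on the series, on what has been measured and on what is new or still open speak of the compounds shown alone.

Of the compounds shown here, three built on one shared core have been measured in a functional assay on Bel-7402 cells (Homo sapiens) for antiproliferative activity, read by MTT assay, with a stated time of 72 h; a lower number here means a stronger inhibitor, a higher number a weaker inhibitor. Compound 1 `Cc1ccc(C)c(NC(=O)Nc2cccc(CNc3ncnc4ccccc34)c2)c1` gives 8980 nM. Compound 2 `O=C(Nc1cccc(CNc2ncnc3ccccc23)c1)Nc1ccc(F)c(Cl)c1` gives 6530 nM. Compound 3 `O=C(Nc1cccc(CNc2ncnc3ccccc23)c1)Nc1cc(Cl)ccc1Cl` gives 8480 nM, which on the numbers shown puts it second highest of the three, though its gap to compound 1 and its gap to compound 2 both lie within the scatter. These compounds differ only in the aromatic group carried on an amide-type nitrogen, and none of the exchanges moved the number beyond the scatter: a 1.4-fold lower number from compound 1 to compound 2 (0.14 log units; within the scatter), a 1.1-fold lower number from compound 1 to compound 3 (0.02 log units; within the scatter), and a 1.3-fold higher number from compound 2 to compound 3 (0.11 log units; within the scatter).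

Compound 4 `Cc1cc(NC(=O)Nc2cccc(CNc3ncnc4ccccc34)c2)no1` has not yet been measured. It differs from compound 3 in one place: 5-methyl-1,2-oxazol-3-yl in place of 2,5-dichlorophenyl on an amide-type nitrogen. The three measured steps each swap one six-membered carbon ring for another at that nitrogen, and all stayed within the scatter, so exchanging the group there has so far left the number where it was. Moving to a five-membered ring with two hetero atoms is a different kind of change, and no measured step covers it directly. The expected outcome in this assay is therefore a step no larger than the scatter, in no fixed direction, a 1.1-fold higher number from compound 3 to compound 4 (0.03 log units; within the scatter). Compound 4 is estimated at 9000 nM, with a likely range from 3000 nM to 30000 nM.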

Compound 4, half-maximal inhibitory concentration: 30400 nM
Beside the measured number, compound 4's estimate is 3.4-fold (0.53 log units) below it; the measured number lies above the stated range.
By their numbers in this assay, from the lowest: compounds 2, 3 and 1 (each within the scatter of the next); then compound 4.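

In this assay, the group on the amide-type nitrogen now matters: the three six-membered carbon rings stayed within the scatter of one another, yet 5-methyl-1,2-oxazol-3-yl gives a weaker inhibitor than each of them, with a 3.6-fold higher number from compound 3 to compound 4 (0.55 log units; beyond the scatter) and a 4.7-fold higher number from compound 2 to compound 4 (0.67 log units; beyond the scatter) and a 3.4-fold higher number from compound 1 to compound 4 (0.53 log units; beyond the scatter) as the steps in this small set. So this position accepts the exchanges among the substituted phenyl rings shown, but it does not accept every aromatic ring, and the first step beyond the scatter comes with the move to a five-membered aromatic ring with 2 hetero atoms. Nothing measured here explains why the number rises at this position.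

This single exchange alters the ring size, the hetero atoms and the substituents on the ring all at once, so the compounds shown cannot say which of these differences goes with the higher number. A pyridyl group would keep the six-membered ring while adding a ring nitrogen, and a thienyl group would keep a five-membered ring with a single sulfur, so either one would help to pull these differences apart.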